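2-Chlorobenzyl in Place of 4-Bromophenyl

The source may hold more compounds than are shown below. What is called first, only, known or untested is meant among the compounds shown, and "the series" means these compounds.

In a functional assay on L02 cells (Homo sapiens) for inhibition, read by Griess assay, with stated times of 1 h and 24 h (on this read-out lower numbers stand for stronger inhibition and higher numbers for weaker inhibition), compound 2 (`Brc1ccc(Nc2nc(/C=C/c3ccccc3)nc3ccsc23)cc1`) gives > 1000000 nM as a limit of the assay and not a number. Compound 1 (`CN(c1ccccc1)c1nc(/C=C/c2ccccc2)nc2ccsc12`) gives > 1000000 nM as a limit too. Compound 3 (`FC(F)(F)c1ccc(Nc2nc(/C=C/c3ccccc3)nc3ccsc23)cc1`) gives > 1000000 nM as a limit as well. Compound 4 (`Clc1ccccc1CNc1nc(/C=C/c2ccccc2)nc2ccsc12`) carries 2-chlorobenzyl in place of 4-bromophenyl on a nitrogen on an aromatic ring. Within the data shown here, two measured steps bear on this change, a step that the two limits leave unreadable from compound 1 to compound 2 and a step that the two limits leave unreadable from compound 2 to compound 3, and neither has a readable size. What the series offers is the limit of > 1000000 nM in this assay, at which 3 of the 3 values shown sit, and nothing finer. No change beyond the scatter is therefore expected, and the expected step is a number no higher from compound 2 to compound 4 (the limit leaves the size open) in this assay terms. For compound 4 the estimated value is 1000000 nM within an expected range from 300000 nM to 3000000 nM in this read-out.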

Compound 4, half-maximal inhibitory concentration: > 1000000 nM
Compound 4: a limit, no number; the forecaster's own chance of this, stated with the estimate: 70%; the middle value sits exactly at the limit.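

Compound 2 and compound 4 both stand only as limits, so no step can be read between them: the limit of > 1000000 nM in this assay, at which 4 of the 4 values shown sit.

The compounds shown leave open whether any of them inhibits at all, and how strongly.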